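The compounds below may be only part of what the source reports. "The series", "measured", "known", "first", "only" and "open" are said of these compounds alone.

The shared core of compound 1 `COc1ccc(-c2c(Cl)c(=O)c3c(OC)cc(OC)cc3n2S(=O)(=O)c2ccc(OC)cc2)cc1` carries, in a functional assay on SUP-B15 cells (Homo sapiens) for antiproliferative activity, with a stated time of 72 h (on this read-out lower numbers stand for an effect already at smaller amounts and higher numbers for an effect only at larger amounts of compound), the only numeric result in this set, with compound 1 giving 17900 nM. Compound 2 `COc1ccc(-c2[nH]c3cc(OC)cc(OC)c3c(=O)c2I)cc1` in this assay reaches only a limit, reported as > 86200 nM. Compound 3 `COc1ccc(-c2cc(=O)c3c(OC)cc(OC)cc3n2S(=O)(=O)c2ccc(C)c([N+](=O)[O-])c2)cc1` likewise gives only a limit in this assay, reported as > 51700 nM. Within the data shown here, compound 3 therefore stands at one of the two limits among the three values shown, and no step between measured compounds that differ in one place is available to anchor it. Compound 4 `COc1ccc(-c2cc(=O)c3c(OC)cc(OC)cc3n2S(=O)(=O)c2ccc(Br)s2)cc1` differs from compound 3 in one place: 5-bromothiophen-2-yl in place of 4-methyl-3-nitrophenyl on a sulfonyl sulfur. With compound 3 sitting at a limit (the limit of > 51700 nM in this assay, at which 1 of the 3 values shown sits), the direction of this step in this assay cannot be read from any measured comparison; the account expects no movement beyond the usual scatter, and a further limit rather than a number is the more likely outcome. The estimated step from compound 3 to compound 4 is an at least 1.1-fold lower number from compound 3 to compound 4 (0.06 log units; that floor lies within the scatter). Compound 4 is accordingly expected to give about 45000 nM in this assay, within a range from 12000 nM to 150000 nM.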

Compound 4, half-maximal effective concentration: > 48200 nM
Compound 4 was reported as a limit; the forecaster's own chance of this, stated with the estimate: 60%; middle value at least 1.0-fold (0.02 log units) from the limit.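

Compound 3 and compound 4 both stand only as limits in this assay, so the step between them cannot be read, in direction or in size. The compounds shown leave open whether 5-bromothiophen-2-yl or 4-methyl-3-nitrophenyl on a sulfonyl sulfur makes any difference to the result in this assay.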